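The compounds below may be only part of what the source reports. "The series", "measured", "known", "first", "only" and "open" are said of these compounds alone.

Compounds measured in a functional assay on MDA-MB-231 cells (Homo sapiens) for cytotoxicity, read by MTT assay, with a stated time of 72 h; a lower number here means a stronger inhibitor, a higher number a weaker inhibitor:
- compound 1 `O=C(CN1CCN(c2nnc(Cc3ccccc3)c3ccccc23)CC1)Nc1c(F)cccc1F` gives 5490 nM
- compound 2 `O=C(CN1CCN(c2nnc(Cc3ccncc3)c3ccccc23)CC1)Nc1ccc(F)c(C(F)(F)F)c1` gives 1.9 nM
- compound 3 `O=C(CN1CCN(c2nnc(Cc3ccccc3)c3ccccc23)CC1)Nc1cc(C(F)(F)F)ccc1Cl` gives 19500 nM

Compound 2 has the lowest of the three numbers, far from compound 1 and further still from compound 3. The next analogue is compound 4 `Cc1cccc(Cl)c1NC(=O)CN1CCN(c2nnc(Cc3ccncc3)c3ccccc23)CC1`, with 2-chloro-6-methylphenyl in place of 4-fluoro-3-(trifluoromethyl)phenyl on an amide-type nitrogen.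

For the measured compounds named here, only one measured step bears on this exchange of amide substituents, a 3.6-fold higher number from compound 1 to compound 3 (0.55 log units; beyond the scatter). That step is modest, but it involves different substituents and a core that differs from the core of compound 2, so it is only a rough guide to size. Going by the values given here, no measured step shows what this change does to compound 2 itself. A moderate rise is expected, since compound 2 at 1.9 nM sits at the extreme low end of a very small set. The expected change is a 13-fold higher number from compound 2 to compound 4 (1.12 log units; beyond the scatter), with wide uncertainty. For compound 4 the estimated value is 25 nM, with an expected range of 2.5 nM to 500 nM.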

Compound 4, half-maximal inhibitory concentration: 2670 nM
The estimate for compound 4 lay 110-fold (2.03 log units) below the measured number; the whole stated range lies below it.
By their numbers in this assay, from the lowest: compound 2; then compound 4; then compound 1; then compound 3.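

In this assay, the substituent on the amide-type nitrogen of the core of compound 2 proves highly sensitive to exchange: a 1400-fold higher number from compound 2 to compound 4 (3.15 log units; beyond the scatter), a large step, whereas the different exchange on the core of compound 1, a 3.6-fold higher number from compound 1 to compound 3 (0.55 log units; beyond the scatter), was modest. With the shared core held constant, the low number of compound 2 does not survive the change to 2-chloro-6-methylphenyl, so that core alone does not secure it. Nothing available on the series accounts for the size of this step.

The step replaces the whole aryl group at once, so the shares of the fluorine, trifluoromethyl, chlorine and methyl substituents remain unresolved. Also open, going by these compounds, is whether a plain phenyl or a 4-methoxyphenyl on the same nitrogen would stay close to compound 2 or fall nearer compound 4.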